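A few compounds are considered here, and "the series" means these few. Any claim that something is new, unique, unknown or untested is made for them only; others in the source may bear on it.

Three amides built on the shared core of compound 1 `CCCC(=O)Nc1c(C(O)(C(F)(F)F)C(F)(F)F)ccc2ccccc12` have been measured in a functional assay (Sus scrofa) with sulfonylurea receptors; K-ATP channels (Homo sapiens) as the target; a higher number here means a larger maximal response, a lower number a smaller maximal response. In this assay compound 1 gives 92%. Compound 2 `CC(C)=CC(=O)Nc1c(C(O)(C(F)(F)F)C(F)(F)F)ccc2ccccc12` carries 2-methylprop-1-en-1-yl on the carbonyl carbon, and in this assay compound 2 gives 96%. Compound 3 `C/C=C/C(=O)Nc1c(C(O)(C(F)(F)F)C(F)(F)F)ccc2ccccc12` carries prop-1-en-1-yl there, and in this assay compound 3 gives 96%, level with compound 2 at the digits shown; the step of no change at the digits printed from compound 2 to compound 3 (within the scatter) and the step of a number 4 percentage points higher from compound 1 to compound 3 (within the scatter) both stay within the scatter, as does a number 4 percentage points higher from compound 1 to compound 2 (within the scatter). Across these three, the group on the carbonyl carbon has made no difference beyond the scatter.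

Compound 4 `COCC(=O)Nc1c(C(O)(C(F)(F)F)C(F)(F)F)ccc2ccccc12` is the next member. Its change from compound 3 is methoxymethyl in place of prop-1-en-1-yl on a carbonyl carbon. Going by the values given here, none of the measured steps covers a methoxymethyl group; the only steps available swapped propyl, prop-1-en-1-yl and 2-methylprop-1-en-1-yl, each within the scatter. On that basis no step beyond the scatter is expected in this assay, and the estimated step of a number 4 percentage points lower from compound 3 to compound 4 (within the scatter) is small. Compound 4 is therefore expected to give about 92% in this assay, with a likely range from 78% to 102%.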

Compound 4, largest response reached (reported as efficacy), in percent of the reference or control that the assay uses: 93%
Compound 4: the middle estimate sits 1 percentage points below what was measured; measured number inside the range.
By their numbers in this assay, from the lowest: compounds 1, 4, 2 and 3 (each within the scatter of the next).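

Methoxymethyl is the first group on this carbonyl carbon to bring in an oxygen, with one hydrogen-bond acceptor by count, and to lose the double bond of prop-1-en-1-yl, yet in this assay that exchange gives a number 3 percentage points lower from compound 3 to compound 4 (within the scatter) and stays inside the usual spread. Measured against the branched alkene, the exchange gives a number 3 percentage points lower from compound 2 to compound 4 (within the scatter), and against the saturated chain, where methoxy replaces ethyl on a saturated chain carbon bound to a carbonyl carbon, it gives a number 1 percentage points higher from compound 1 to compound 4 (within the scatter), so a chain oxygen has so far left the maximal response as unchanged as the double bonds did. No supporting measurement bears on this result.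

The compounds shown leave open whether the maximal response would hold with a different kind of group at this position, such as an amine, a carboxylic acid, a phenyl ring or a much longer chain. They also leave open whether this flat picture extends to changes elsewhere on the shared core, since all four compounds differ only in the group on the carbonyl carbon.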